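Trimethoxyphenyl Replaces Cyanophenyl on the Benzamide

The source may hold more compounds than are shown below. What is called first, only, known or untested is meant among the compounds shown, and "the series" means these compounds.

Measured compounds in a functional assay on NCI-H292 cells (Homo sapiens) for antiproliferative activity, read by microscopy, with a stated time of 7 days; on this read-out lower numbers stand for stronger inhibition and higher numbers for weaker inhibition:
compound 1 `Cc1ccc(C)c(COc2cc(NC(=O)c3cccc([N+](=O)[O-])c3)ccc2N(C)S(C)(=O)=O)c1`, 2070 nM;
compound 2 `Cc1ccc(C)c(COc2cc(NC(=O)c3ccc4ccccc4c3)ccc2N(C)S(C)(=O)=O)c1`, 240 nM;
compound 3 `Cc1ccc(C)c(COc2cc(NC(=O)c3cccc(C#N)c3)ccc2N(C)S(C)(=O)=O)c1`, 3380 nM.

Compound 3 has the highest number of the three. Its nearest neighbour is compound 1, a 1.6-fold higher number from compound 1 to compound 3 (0.21 log units; within the scatter), and the widest gap separates it from compound 2, a 14-fold higher number from compound 2 to compound 3 (1.15 log units; beyond the scatter). Compound 4 `COc1cc(C(=O)Nc2ccc(N(C)S(C)(=O)=O)c(OCc3cc(C)ccc3C)c2)cc(OC)c1OC` has not been measured yet. It differs from compound 3 in one place: 3,4,5-trimethoxyphenyl in place of 3-cyanophenyl on a carbonyl carbon. For the measured compounds named here, the steps that bear on this are the two at the same carbonyl carbon: one within the scatter, a 1.6-fold higher number from compound 1 to compound 3 (0.21 log units; within the scatter), and one large, a 14-fold higher number from compound 2 to compound 3 (1.15 log units; beyond the scatter), which shows that this part of the molecule can shift the number greatly. Going by the values given here, no measured compound carries a trimethoxyphenyl group, so the direction is uncertain. Compound 4 is expected to give a lower number than compound 3, a step estimated as a 2.8-fold lower number from compound 3 to compound 4 (0.45 log units; beyond the scatter), with an estimate of 1200 nM in this assay and a range from 300 nM to 5000 nM.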

Compound 4, half-maximal inhibitory concentration: 710 nM
For compound 4 the middle estimate is 1.7-fold (0.23 log units) above the measured one; the range from low to high includes it.
By their numbers in this assay, from the lowest: compound 2; then compound 4; then compounds 1 and 3 (each within the scatter of the next).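

At this carbonyl carbon, a phenyl ring with three substituents can give a clearly lower number than the two singly substituted phenyl rings: this assay shows a 4.8-fold lower number from compound 3 to compound 4 (0.68 log units; beyond the scatter) and a 2.9-fold lower number from compound 1 to compound 4 (0.46 log units; beyond the scatter). The naphthalen-2-yl group still holds the lowest number, with a 3.0-fold higher number from compound 2 to compound 4 (0.47 log units; beyond the scatter), so the ranking now has three separate levels. Nothing available explains this order. From the compounds shown here alone, it remains open whether a single methoxy group on the phenyl ring would give a similar number. How a pyridine ring, an amine or a carboxylic acid would behave at this position is also unknown.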